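Cytotoxicity of aryl-oxygen substituents on the shared core

The source may report more compounds than this note shows. Statements on the series, on what has been measured and on what is new or still open speak of the compounds shown alone.

Among the compounds with values here, compound 1 `COC(=O)CNC(=O)CCC(=O)Oc1ccc(C[C@H]2C(=O)OC[C@@H]2Cc2ccc(OC)c(OC)c2)cc1OC` is the only member of the set with a numeric reading: in an ADME assay on HeLa cells (Homo sapiens) for cytotoxicity, read by MTT assay (a higher number here means a weaker inhibitor, a lower number a stronger inhibitor), compound 1 gives 179000 nM. Compound 2 `COc1ccc(C[C@H]2COC(=O)[C@@H]2Cc2ccc(OCC(=O)Nc3ccccc3)c(OC)c2)cc1OC` reaches only the limit of this assay, >= 600000 nM. Compound 3 `COc1ccc(-n2cc(COc3ccc(C[C@H]4C(=O)OC[C@@H]4Cc4ccc(OC)c(OC)c4)cc3OC)nn2)cc1` likewise sits at the limit, >= 600000 nM. Within the data shown here, the one measured step starting from a number is an at least 3.3-fold higher number from compound 1 to compound 2 (0.52 log units; beyond the scatter); its size is bounded only from below, since the limit of >= 600000 nM in this assay, at which 2 of the 3 values shown sit, is where compound 2 lands.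

Compound 4 `COc1ccc(C[C@H]2COC(=O)[C@@H]2Cc2ccc(OCc3cn(-c4ccccc4)nn3)c(OC)c2)cc1OC` differs from compound 1 as follows. a group of 12 heavy atoms (9 carbon, 3 nitrogen; one five-membered aromatic ring with 3 hetero atoms, one six-membered aromatic ring of carbon only) in place of a group of 12 heavy atoms (7 carbon, 1 nitrogen, 4 oxygen; no ring), on an oxygen on an aromatic ring

The step from compound 1 to compound 2 also exchanges the open chain on this oxygen for a group carrying a six-membered aromatic ring of carbon only, and the reading moves to the limit; the change to compound 4 is of the same kind. Among the measured compounds shown here, for compound 3 and compound 4 no measured pair exists, so only the limit of compound 3 can be noted. Compound 4 is therefore expected to give 500000 nM (range 200000 nM to 1500000 nM), which means an expected 2.8-fold higher number from compound 1 to compound 4 (0.45 log units; beyond the scatter), with a fair chance that this assay reports only its limit.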

Compound 4, half-maximal inhibitory concentration: 124000 nM
Estimate against measurement, compound 4: 4.0-fold (0.61 log units) above; measured number below the stated range.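

In this assay, the (1-phenyl-1H-1,2,3-triazol-4-yl)methyl group on this oxygen on an aromatic ring reads no differently from the open chain of compound 1 (a 1.4-fold lower number from compound 1 to compound 4 (0.16 log units; within the scatter)), so carrying aromatic rings here does not by itself bring a reading at the limit. Two single changes separate compound 4 from limit readings: 1-phenyl-1H-1,2,3-triazol-4-yl in place of phenylcarbamoyl (an at least 4.8-fold lower number from compound 2 to compound 4 (0.68 log units; beyond the scatter)), and hydrogen in place of methoxy on an aromatic carbon (an at least 4.8-fold lower number from compound 3 to compound 4 (0.68 log units; beyond the scatter)). Both steps are bounded from one side only: the limit of >= 600000 nM in this assay, at which 2 of the 4 values shown sit.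

From the compounds shown here alone, the true size of these two steps remains open. Also open, going by these compounds, is whether an amine or a carboxylic acid in place of that methoxy, or a longer chain on the oxygen, would give a numeric reading.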